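This account rests on a few compounds, and the source may have more. Where it says the series, first, only, none or still open, it means among the compounds named here.

Of the compounds shown here, three sharing one core have been tested in an ADME assay on MT4 cells (Homo sapiens) for cytotoxicity, read by MTT assay, with a stated time of 96 h; on this read-out higher numbers stand for lower toxicity in this test and lower numbers for higher toxicity in this test. Compound 1 `O=C(CN1CCCCC1)Nc1ccc(-c2nc3cc(C(F)(F)F)ccc3[nH]2)cc1` gives 6000 nM, compound 2 `CC(=O)Nc1ccc(-c2nc3cc(C(F)(F)F)ccc3[nH]2)cc1` gives 19000 nM, and compound 3 `CCC(=O)Nc1ccc(-c2nc3ccccc3[nH]2)cc1` gives 35000 nM, the highest of the three numbers; its gap to compound 2 lies within the scatter, while its gap to compound 1 lies beyond it. Going by the values given here, the single measured step, a 3.2-fold higher number from compound 1 to compound 2 (0.50 log units; beyond the scatter), concerns a different change. Compound 4 `CCC(=O)Nc1ccc(-c2nc3cc(C(F)(F)F)ccc3[nH]2)cc1` differs from compound 3 by trifluoromethyl in place of hydrogen on an aromatic carbon. Among the compounds with values here, no measured step bears on this change; compounds 2 and 3, which differ in more than one place, give numbers within the scatter of each other. Compound 4 is therefore expected to show no step beyond the scatter, a 1.4-fold lower number from compound 3 to compound 4 (0.15 log units; within the scatter). The estimate for compound 4 is 25000 nM, with a range from 10000 nM to 60000 nM.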

Compound 4, half-maximal cytotoxic concentration: >= 100000 nM
Compound 4 ended at the assay's limit; the forecaster's own chance of this, stated with the estimate: 10%; middle value at least 4.0-fold (0.60 log units) away from the limit.
By their numbers in this assay, from the lowest: compound 1; then compounds 2 and 3 (each within the scatter of the next). At a limit, above all of these: compound 4.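

Trifluoromethyl in place of hydrogen on this aromatic carbon raises the number, with an at least 2.8-fold higher number from compound 3 to compound 4 (0.45 log units; beyond the scatter), so in this assay the change at this position points towards lower toxicity in this test. With trifluoromethyl in place, the group on the chain also matters: methyl in place of hydrogen gives an at least 5.2-fold higher number from compound 2 to compound 4 (0.72 log units; beyond the scatter), and methyl in place of piperidin-1-yl gives an at least 16-fold higher number from compound 1 to compound 4 (1.22 log units; beyond the scatter). Compound 4 stands at a limit of the assay and not at a number: the limit of >= 100000 nM in this assay, at which 1 of the 4 values shown sits.

As far as these compounds go, how far compound 4 lies past this limit stays open. So does whether a nitrile or a chlorine on this aromatic carbon, or a longer chain on the carbonyl, would move the number the same way.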